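This account rests on a few compounds, and the source may have more. Where it says the series, first, only, none or still open, it means among the compounds named here.

Measured compounds and their values:

Compound 1 `CC(C)(C)Cn1cc2c(Cl)nc(N)nc2n1`. In an assay on CHO cells for displacement of a labelled ligand from adenosine receptor A3 (Homo sapiens), read by scintillation counting, with a stated time of 3 h (on this read-out higher numbers stand for weaker inhibition and lower numbers for stronger inhibition), compound 1 gives > 60000 nM, which is a limit of the assay and not a number.

Compound 2 `CC(C)n1cc2c(Cl)nc(N)nc2n1`. In this assay compound 2 gives > 100000 nM, again a limit of the assay.

Compound 3 `CC(C)n1cc2c(Cl)nc(NC(=O)c3ccc(F)cc3)nc2n1`. In this assay compound 3 gives > 60000 nM, also a limit of the assay.

The change from compound 2 to compound 1 is neopentyl in place of isopropyl on an aromatic nitrogen. The step it made, a step that the two limits leave unreadable from compound 2 to compound 1, cannot be sized, because both ends rest on limits: the limit of > 100000 nM in this assay, at which 1 of the 3 values shown sits, and (the limit of > 60000 nM in this assay, at which 2 of the 3 values shown sit). Compound 3 and compound 2 differ in their cores; the difference between the two cores is not broken down here.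

Compound 4 `CC(C)(C)Cn1cc2c(Cl)nc(NC(=O)c3ccc(F)cc3)nc2n1` is not yet measured. It differs from compound 3 by neopentyl in place of isopropyl on an aromatic nitrogen, the same change as from compound 2 to compound 1, the place being described in identical words. For the measured compounds named here, the single precedent for this change offers no readable size, so the expected step that the limit leaves unreadable from compound 3 to compound 4 is set at no change. That expectation rests on compound 3 giving > 60000 nM as a limit. It rests equally on compound 1, which carries the neopentyl group, giving > 60000 nM as a limit.

For compound 4 the estimate in this assay is 100000 nM, with a range from 30000 nM to 300000 nM, and the assay is expected to return only a limit once more.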

Compound 4, inhibition constant: 5900 nM
Compound 4: middle estimate off by 17-fold (1.23 log units), on the high side; the measured number lies below the stated range.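

On the core that carries the amide, neopentyl in place of isopropyl on an aromatic nitrogen gives an at least 10-fold lower number from compound 3 to compound 4 (1.00 log units; beyond the scatter) in this assay, a step beyond the scatter and the only sized result for this change in the series. That size is only a minimum: compound 3 gives > 60000 nM, which is a limit of the assay and not a number. On the core with the free amino group the same change cannot be read, since both ends rest on limits, so the series shows that the change can go with a lower number on one core, but it does not show that a step of this size carries from one core to another, and it gives no second sized case to set beside the first.

As far as these compounds go, it remains open whether a longer chain, a cyclopentyl or a benzyl group on the same aromatic nitrogen would lower the number further on the amide-bearing core. Also open, from the compounds shown here alone, are how far the neopentyl step depends on the fluorobenzoyl group, for instance with an acetyl group in its place, and whether an amine in place of the chlorine would keep the number that compound 4 gives.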